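Replacing dipropylamino with an arylamino group in the HeLa assay

This account rests on a few compounds, and the source may have more. Where it says the series, first, only, none or still open, it means among the compounds named here.

Compound 1 `CCOc1ccccc1NC1=CC(=O)c2c(nc3n2[C@H]2OC[C@@H](O)[C@H]2OC3)C1=O`: 8300 nM
Compound 2 `CCCN(CCC)C1=CC(=O)c2c(nc3n2[C@H]2OC[C@@H](O)[C@H]2OC3)C1=O`: > 16000 nM

In a functional assay on HeLa cells (Homo sapiens) for inhibition, read by sulforhodamine B assay (a lower number here means a stronger inhibitor, a higher number a weaker inhibitor), compound 2 gives > 16000 nM. This value is a limit of the assay and not a number, so the starting point of the step has no exact position.

Compound 3 `O=C1C(Nc2cccc(Cl)c2)=CC(=O)c2c1nc1n2[C@H]2OC[C@@H](O)[C@H]2OC1` shares the core of compound 2 but carries (3-chlorophenyl)amino in place of dipropylamino on a double-bonded ring carbon. Among the compounds with values here, no step between measured compounds is available as a guide. Within the data shown here, the only numerical reading on this core is from compound 1, at 8300 nM in this assay, and the expectation leans on that value. A modest gain in inhibition is therefore expected, though it may not clear the assay limit by much.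

The expected step runs an at least 2.2-fold lower number from compound 2 to compound 3 (0.35 log units; beyond the scatter). The estimate for compound 3 is 7000 nM, with an expected range of 2500 nM to 16000 nM.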

Compound 3, half-maximal inhibitory concentration: 7970 nM
Compound 3: middle estimate off by 1.1-fold (0.06 log units), on the low side, within the range that was stated.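

In this assay, exchanging 2-ethoxyphenyl for 3-chlorophenyl on the amine nitrogen gives a 1.0-fold lower number from compound 1 to compound 3 (0.02 log units; within the scatter), so two differently substituted phenyl rings on this nitrogen cannot be told apart on the shared core. The exchange of dipropylamino for (3-chlorophenyl)amino on the double-bonded ring carbon gives an at least 2.0-fold lower number from compound 2 to compound 3 (0.30 log units; that floor lies within the scatter), which shows only a floor and not the full size of the step. Compound 2 stands at a limit of the assay and not at a number: the limit of > 16000 nM in this assay, at which 1 of the 3 values shown sits.

As far as these compounds go, it remains open whether the aromatic ring is needed at all, or whether propylamino, which keeps the hydrogen on the nitrogen but carries a single chain, would read like compound 3. From the compounds shown here alone, how a carboxylic acid or an amine on the phenyl ring would read also remains open.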